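Lengthening the Sulfonyl Chain from Methyl to Decyl

The source may report more compounds than this note shows. Statements on the series, on what has been measured and on what is new or still open speak of the compounds shown alone.

Going by the values given here, in a physicochemical assay for lipophilicity (a higher number here means a more lipophilic compound, a lower number a more polar compound), compound 3 `CS(=O)(=O)c1ccc(O)c(C(=O)Nc2ccc(C(F)(F)F)cc2)c1` gives 2.52, the lowest of the three numbers measured so far. Compound 1 `CCCCCCCCS(=O)(=O)c1ccc(O)c(C(=O)Nc2ccc(C(F)(F)F)cc2)c1` gives 6.3, and compound 2 `CCCCCCCCCCS(=O)(=O)c1ccc(O)c(C(=O)Nc2ccc(Br)cc2)c1` gives 7.36. The next compound to be measured, compound 4 `CCCCCCCCCCS(=O)(=O)c1ccc(O)c(C(=O)Nc2ccc(C(F)(F)F)cc2)c1`, has nonyl in place of hydrogen on a saturated chain carbon bound to a sulfonyl sulfur. The same difference can also be read as methyl to decyl.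

Among the compounds with values here, the one measured step at this place is a number 3.78 log units lower from compound 1 to compound 3 (beyond the scatter), a large drop with hydrogen in place of heptyl. Read in reverse, this step points to a large rise for compound 4, and nonyl is the longer chain. Compound 2 also carries decyl and stands at 7.36, which gives a second guide to the likely level. An upward move somewhat larger than the measured one is therefore expected, estimated as a number 4.88 log units higher from compound 3 to compound 4 (beyond the scatter). Compound 4 is expected to read 7.4, within an estimated range of 7 to 7.8.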

Compound 4, partition coefficient: 7.38
Compound 4: middle estimate off by 0.02 log units, on the high side, and the stated range covers the measured number.
By their numbers in this assay, from the lowest: compound 3; then compound 1; then compounds 2 and 4 (each within the scatter of the next).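

The full change from methyl to decyl gives a number 4.86 log units higher from compound 3 to compound 4 (beyond the scatter) in this assay and the last stretch of it, ethyl in place of hydrogen on a saturated chain carbon, eight bonds along the chain from a sulfonyl sulfur, still gives a number 1.08 log units higher from compound 1 to compound 4 (beyond the scatter) as a large step of its own. Across compound 3, compound 1 and compound 4, which all carry trifluoromethyl, the number has therefore not levelled off at the chain of compound 1. With decyl held, trifluoromethyl in place of bromo on an aromatic carbon gives a number 0.02 log units higher from compound 2 to compound 4 (within the scatter) so compound 2 and compound 4 cannot be told apart in this assay at this chain length.

Nothing measured here gives a reason for these steps. On these data alone, whether a longer chain than decyl, or a chain ending in a carboxylic acid or an amine, would carry the rise further stays open, as does whether bromo and trifluoromethyl also match on the methyl compound.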